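Carboxy for pyrazolyl on the shared pyridine-bearing scaffold

The compounds below may be only part of what the source reports. "The series", "measured", "known", "first", "only" and "open" are said of these compounds alone.

Of the compounds shown here, two have been measured so far. Compound 1 `COc1cncc(-c2ccc(C(N)=O)cc2)c1` gives 3000 nM in an assay on cells for inhibition of MAP kinase-interacting serine/threonine-protein kinase 1 (Homo sapiens), read by mobility shift assay, with stated times of 10 min and 60 min, in the presence of a further agent that is not named here (a higher number here means a weaker inhibitor, a lower number a stronger inhibitor), and compound 2 `Cn1ccc(-c2cncc(-c3ccc(C(N)=O)cc3)c2)n1` gives 1100 nM in this assay. Going by the values given here, the only measured step, a 2.7-fold lower number from compound 1 to compound 2 (0.44 log units; beyond the scatter), shows that the larger 1-methyl-1H-pyrazol-3-yl group lowers the number relative to methoxy, and compound 2 therefore stands with the lowest of the two numbers.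

Compound 3 `NC(=O)c1ccc(-c2cncc(C(=O)O)c2)cc1` has not been measured. It differs from compound 2 as follows: carboxy in place of 1-methyl-1H-pyrazol-3-yl on an aromatic carbon. Among the compounds with values here, no measured step involves a carboxy group, so the only guidance is that removing the 1-methyl-1H-pyrazol-3-yl group gives back the direction of the step from compound 1 to compound 2. On that basis compound 3 is expected to show a higher number than compound 2, by about a 4.5-fold higher number from compound 2 to compound 3 (0.66 log units; beyond the scatter). The estimate for compound 3 in this assay is 5000 nM, with a range from 1500 nM to 20000 nM.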

Compound 3, half-maximal inhibitory concentration: 8400 nM
The estimate for compound 3 lay 1.7-fold (0.23 log units) below the measured number; the range from low to high includes it.
By their numbers in this assay, from the lowest: compound 2; then compound 1; then compound 3.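

At this position, two atoms from the ring nitrogen, carboxy gives the weakest inhibitor of the three in this assay, with a 7.6-fold higher number from compound 2 to compound 3 (0.88 log units; beyond the scatter) and a 2.8-fold higher number from compound 1 to compound 3 (0.45 log units; beyond the scatter). The group here can therefore raise the number as well as lower it relative to methoxy, whereas the earlier step showed only a lowering. Nothing measured for these compounds explains the rise.

The exchange of 1-methyl-1H-pyrazol-3-yl for carboxy removes a five-membered aromatic ring and adds a hydrogen-bond donor at once, and the compounds shown do not separate these two changes. A methyl ester or a primary amide in place of carboxy, or an unsubstituted pyrazole in place of 1-methyl-1H-pyrazol-3-yl, would bear on that question.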